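Swapping methoxy for chloro on the benzyl ring

This account rests on a few compounds, and the source may have more. Where it says the series, first, only, none or still open, it means among the compounds named here.

Compound 1 `COc1ccc(Cn2cc(CNC(=O)c3ccc([N+](=O)[O-])o3)nn2)cc1O`: in an ADME assay on MRC5 cells (Homo sapiens) for cytotoxicity (on this read-out lower numbers stand for stronger inhibition and higher numbers for weaker inhibition), compound 1 gives 189000 nM.
Compound 2 `COc1cc(Cn2cc(CNC(=O)c3ccc([N+](=O)[O-])o3)nn2)ccc1O`: in this assay compound 2 gives 182000 nM.
Compound 3 `COc1cc(Cn2cc(CNC(=O)c3ccc([N+](=O)[O-])o3)nn2)ccc1F`: in this assay compound 3 gives 155000 nM.

Compound 3 has the lowest of the three numbers, yet its gaps to the other two are within the scatter: a 1.2-fold lower number from compound 2 to compound 3 (0.07 log units; within the scatter) and a 1.2-fold lower number from compound 1 to compound 3 (0.09 log units; within the scatter). The remaining step, a 1.0-fold lower number from compound 1 to compound 2 (0.02 log units; within the scatter), is within the scatter as well, so the three measured compounds cannot be told apart on this read-out.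

Compound 4 `O=C(NCc1cn(Cc2ccc(F)c(Cl)c2)nn1)c1ccc([N+](=O)[O-])o1` differs from compound 3 in one place: chloro in place of methoxy on an aromatic carbon. All three measured steps changed groups on the same six-membered aromatic ring of carbon only, and none moved the number beyond the scatter; the closest parallel is a 1.2-fold lower number from compound 2 to compound 3 (0.07 log units; within the scatter), where one small group on an aromatic carbon replaced another. Within the data shown here, no measured step tests chloro itself, so the expectation rests on that pattern alone. The expected step is a 1.0-fold lower number from compound 3 to compound 4 (0.01 log units; within the scatter), that is, no change beyond the scatter. Compound 4 is estimated at 150000 nM, with a range from 80000 nM to 280000 nM.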

Compound 4, half-maximal inhibitory concentration: 254000 nM
The estimate for compound 4 lay 1.7-fold (0.23 log units) below the measured number; the measured number falls inside the stated range.
By their numbers in this assay, from the lowest: compounds 3, 2, 1 and 4 (each within the scatter of the next).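

Compound 4 carries the first ring here with no oxygen on it, yet replacing methoxy with chloro while keeping fluoro stays within the scatter in this assay (a 1.6-fold higher number from compound 3 to compound 4 (0.21 log units; within the scatter)). The two hydroxy-bearing compounds give the same picture (a 1.4-fold higher number from compound 2 to compound 4 (0.14 log units; within the scatter); a 1.3-fold higher number from compound 1 to compound 4 (0.13 log units; within the scatter)), so 3-chloro-4-fluorophenyl cannot be told apart from the three earlier rings on this read-out. Nothing available offers a reason for this result.

The compounds shown leave open whether a group of another kind at this position, such as an amine or a carboxylic acid, would move the number beyond the scatter. They also leave open whether these rings would still be indistinguishable if the shared core were changed.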